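The source may report more compounds than this note shows. Statements on the series, on what has been measured and on what is new or still open speak of the compounds shown alone.

In a functional assay on Caco-2 cells (Homo sapiens), read by MTT assay, with a stated time of 48 h (a higher number here means a weaker inhibitor, a lower number a stronger inhibitor), compound 3 (`CCn1c(C(=O)NCCCN(C)C)ccc1C(CC)(CC)c1ccc(OCC(O)C(C)(C)C)c(C)c1`) gives 1900 nM, within the scatter of both compound 1 (`CCn1c(C(=O)NCCCN(C)C)ccc1C(CC)(CC)c1ccc(OCC(=O)C(C)(C)C)c(C)c1`) at 1400 nM and compound 2 (`CCN(CC)CCNC(=O)c1ccc(C(CC)(CC)c2ccc(OCC(O)C(C)(C)C)c(C)c2)n1CC`) at 2310 nM. Compound 4 (`CCn1c(C(=O)NCC(OC)OC)ccc1C(CC)(CC)c1ccc(OCC(O)C(C)(C)C)c(C)c1`) differs from compound 3 by dimethoxymethyl in place of 2-(dimethylamino)ethyl on a saturated chain carbon bound to an amide-type nitrogen: dimethoxymethyl in place of 2-(dimethylamino)ethyl. Two measured steps offer a guide. Changing the amide side chain gave a 1.2-fold lower number from compound 2 to compound 3 (0.08 log units; within the scatter), and 1-hydroxy-2,2-dimethylpropyl in place of (tert-butyl)carbonyl gave a 1.4-fold higher number from compound 1 to compound 3 (0.13 log units; within the scatter). For the measured compounds named here, neither step goes beyond the scatter, but no measured compound carries dimethoxymethyl, so this replacement is untested and the range stays wide. The estimated step is a 1.3-fold higher number from compound 3 to compound 4 (0.12 log units; within the scatter), with no change beyond the scatter expected in this assay. For compound 4 the expected value is 2500 nM, with an estimated range of 800 nM to 9000 nM.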

Compound 4, half-maximal inhibitory concentration: > 50000 nM
Compound 4: a limit, no number (the forecaster's own chance of this, stated with the estimate: 15%); middle value at least 20-fold (1.30 log units) away from the limit.
By their numbers in this assay, from the lowest: compounds 1, 3 and 2 (each within the scatter of the next). At a limit, above all of these: compound 4.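

In this assay compound 4 is a limit, not a number: the limit of > 50000 nM in this assay, at which 1 of the 4 values shown sits. The amide side chain, which showed no change beyond the scatter between compound 2 and compound 3, is sensitive to this replacement: dimethoxymethyl gives an at least 26-fold higher number from compound 3 to compound 4 (1.42 log units; beyond the scatter), and the comparison with the diethylamino side chain gives an at least 21-fold higher number from compound 2 to compound 4 (1.33 log units; beyond the scatter). Compound 4 is the only compound shown whose side chain has no amine nitrogen.

As far as these compounds go, whether the amine nitrogen itself is required, or the dimethoxymethyl group is specifically poorly tolerated, remains open. A side chain ending in a primary amine, a hydroxyl or a carboxylic acid would help separate these readings.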